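Moving the Bromine Around the Phenyl Ring

The source may hold more compounds than are shown below. What is called first, only, known or untested is meant among the compounds shown, and "the series" means these compounds.

Measured so far:
compound 1 `N=C(N)N/N=C/c1cn(-c2ccc([N+](=O)[O-])cc2[N+](=O)[O-])nc1-c1ccccc1Br`: 78.1%
compound 2 `N=C(N)N/N=C/c1cn(-c2ccc([N+](=O)[O-])cc2[N+](=O)[O-])nc1-c1cccc(Br)c1`: 81.7%

In a functional assay on the whole organism (Ear) for inhibition, with Mus musculus as the target, with a stated time of 30 min, at a dose of 50 mg/kg by the intraperitoneal route (on this read-out lower numbers stand for less inhibition and higher numbers for more inhibition at the one dose given (going by the name of the read-out)), compound 2 gives 81.7%, and compound 1 gives 78.1%. Among the compounds with values here, the two sit together, since the only measured step, a number 3.6 percentage points higher from compound 1 to compound 2 (within the scatter), stays within the scatter.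

Compound 3 `N=C(N)N/N=C/c1cn(-c2ccc([N+](=O)[O-])cc2[N+](=O)[O-])nc1-c1ccc(Br)cc1` differs from compound 2 by 4-bromophenyl in place of 3-bromophenyl on an aromatic carbon. Within the data shown here, the one step that bears on this, a number 3.6 percentage points higher from compound 1 to compound 2 (within the scatter), also shifts the bromine around the same ring and changed nothing beyond the scatter, so no step beyond the scatter is expected here either: a number 1.7 percentage points lower from compound 2 to compound 3 (within the scatter). Compound 3 is therefore estimated at 80%, with a range from 66% to 92%.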

Compound 3, a percentage reported as inhibition, in the whole organism at one dose (the size of the read-out at that dose, not a potency): 69.6%
For compound 3 the middle estimate is 10.4 percentage points above the measured one; measured number inside the range.
By their numbers in this assay, from the lowest: compounds 3, 1 and 2 (each within the scatter of the next, the first and the last beyond it).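

In this assay, within the data shown here, the place of the bromine on the phenyl ring can matter: 4-bromophenyl in place of 3-bromophenyl gives a number 12.1 percentage points lower from compound 2 to compound 3 (beyond the scatter), the only step so far beyond the scatter, though a modest one. With 4-bromophenyl in place of 2-bromophenyl the result is a number 8.5 percentage points lower from compound 1 to compound 3 (within the scatter), so compound 1 cannot be told apart from either of the other two. Nothing available explains this difference between the bromine positions. Still open, as far as these compounds go, is what a phenyl ring carrying chlorine, a methoxy group or an amine instead of bromine would give.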